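Aryl variation on the shared diol core: compound 4

This account rests on a few compounds, and the source may have more. Where it says the series, first, only, none or still open, it means among the compounds named here.

Compound 1 `CC1(C)CCC[C@]2(C)[C@@H](CC[C@@](C)(O)/C=C/c3cccc([N+](=O)[O-])c3)[C@](C)(O)CC[C@@H]12` gives 3380 nM in a functional assay on HeLa cells (Homo sapiens) for cytotoxicity, read by MTT assay, with a stated time of 48 h; on this read-out lower numbers stand for stronger inhibition and higher numbers for weaker inhibition.
Compound 2 `COc1cccc(OC)c1/C=C/[C@](C)(O)CC[C@@H]1[C@@]2(C)CCCC(C)(C)[C@@H]2CC[C@@]1(C)O` gives 48200 nM in this assay.
Compound 3 `Cc1cccc(/C=C/[C@](C)(O)CC[C@@H]2[C@@]3(C)CCCC(C)(C)[C@@H]3CC[C@@]2(C)O)c1C` gives 3700 nM in this assay.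

Compound 3 stands second highest of the three numbers: its nearest neighbour is compound 1 with a 1.1-fold higher number from compound 1 to compound 3 (0.04 log units; within the scatter), its furthest compound 2 with a 13-fold lower number from compound 2 to compound 3 (1.11 log units; beyond the scatter). The step to compound 4 `CC1(C)CCC[C@]2(C)[C@@H](CC[C@@](C)(O)/C=C/c3ccc(F)cc3)[C@](C)(O)CC[C@@H]12` is 4-fluorophenyl in place of 2,3-dimethylphenyl on a double-bonded chain carbon bound to a double-bonded chain carbon. The aryl steps measured so far are uneven: a 14-fold higher number from compound 1 to compound 2 (1.15 log units; beyond the scatter) is large, while a 1.1-fold higher number from compound 1 to compound 3 (0.04 log units; within the scatter) stays within the scatter. Going by the values given here, no step to a 4-fluorophenyl exists here. Since the two unsubstituted-pattern and dimethyl aryl compounds sit close together, a step of about a 1.1-fold higher number from compound 3 to compound 4 (0.03 log units; within the scatter) is expected for compound 4, with no direction beyond the scatter assumed. Compound 4 is estimated at 4000 nM, range 1500 nM to 12000 nM.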

Compound 4, half-maximal inhibitory concentration: 3460 nM
For compound 4 the middle estimate is 1.2-fold (0.06 log units) above the measured one; the range from low to high includes it.
By their numbers in this assay, from the lowest: compounds 1, 4 and 3 (each within the scatter of the next); then compound 2.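

At this place on the double-bonded chain carbon, 4-fluorophenyl reads like the other two non-methoxy aryl groups: a 1.1-fold lower number from compound 3 to compound 4 (0.03 log units; within the scatter) and a 1.0-fold higher number from compound 1 to compound 4 (0.01 log units; within the scatter) are both within the scatter. Compounds 1, 3 and 4 therefore form a flat group despite their different aryl substituents, and compound 2 goes against this, with a 14-fold lower number from compound 2 to compound 4 (1.14 log units; beyond the scatter) as a large step. Nothing measured here explains why 2,6-dimethoxyphenyl stands apart.

As far as these compounds go, it remains open whether the methoxy groups themselves or their placement on the ring set compound 2 apart. Also open, from the compounds shown here alone, is how an aryl group bearing an amine or a carboxylic acid would read in this assay at this place.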